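Urea series: acid to primary amide, solubility outlook

The source may report more compounds than this note shows. Statements on the series, on what has been measured and on what is new or still open speak of the compounds shown alone.

In a physicochemical assay for solubility, read by nephelometry, in phosphate buffer, measured as kinetic solubility, at pH 6.5, tested at 10 mg/mL (on this read-out lower numbers stand for lower solubility and higher numbers for higher solubility), compound 1 `CC(C)(CC(=O)Nc1ccc(F)c(C(F)(F)F)c1)C(=O)O` gives 25 ug/mL. Compound 2 `O=C(Nc1ccc(F)c(C(F)(F)F)c1)NC1(C(=O)O)CCC1` reaches only a limit in this assay, recorded as > 100 ug/mL. Compound 2 thus stands at the limit of > 100 ug/mL in this assay, at which 1 of the 2 values shown sits, and its true value is not known. Among the measured compounds no pair differs in a single place, so no measured step is available to size the effect of any one edit.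

Compound 3 `CC(C)(NC(=O)Nc1ccc(F)c(C(F)(F)F)c1)C(N)=O` has not yet been measured in this assay. It differs from compound 2 by 1-carbamoyl-1-methylethyl in place of 1-carboxycyclobutyl on an amide-type nitrogen whose other neighbour is a carbonyl carbon. The expected step, an at least 2.5-fold lower number from compound 2 to compound 3 (0.39 log units; beyond the scatter), is a decrease beyond the usual scatter, though its size cannot be fixed while compound 2 remains a limit. Compound 3 is therefore expected to fall between the two measured results, nearer compound 1, whose value of 25 ug/mL is the only numeric anchor in the set. For compound 3 the estimate in this assay is 40 ug/mL, with a range from 10 ug/mL to 150 ug/mL.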

Compound 3, solubility: 50 ug/mL
Beside the measured number, compound 3's estimate is 1.3-fold (0.10 log units) below it; low and high end bracket the measured number.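

Working notes: in this assay, 1-carbamoyl-1-methylethyl in place of 1-carboxycyclobutyl on an amide-type nitrogen gives an at least 2.0-fold lower number from compound 2 to compound 3 (0.30 log units; that floor lies within the scatter), the first step at this position that can be sized at all, though only as a floor. Against the other measured neighbour, (1-carbamoyl-1-methylethyl)amino in place of 2-carboxy-2-methylpropyl on a carbonyl carbon gives a 2.0-fold higher number from compound 1 to compound 3 (0.30 log units; within the scatter), so this change does not separate these two compounds on this read-out, and a member without a carboxy-bearing group now gives a numeric reading in the same range as compound 1. The reading for compound 2 remains a limit and not a number, so the first step cannot be called a real decrease on its floor alone: the limit of > 100 ug/mL in this assay, at which 1 of the 3 values shown sits.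

As far as these compounds go, the true size of the step to compound 3 remains open, and the change of the acid to the primary amide is still not separated from the change of the cyclobutyl ring to the open gem-dimethyl arrangement. From the compounds shown here alone, whether 1-carboxy-1-methylethyl or 1-carbamoylcyclobutyl on that nitrogen, or an amine in that place, would read nearer compound 2 or compound 3 also remains open.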